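The source may hold more compounds than are shown below. What is called first, only, known or untested is meant among the compounds shown, and "the series" means these compounds.

Measured so far in a functional assay on SK-MEL-28 cells (Homo sapiens) for inhibition, read by sulforhodamine B assay, with a stated time of 48 h; a lower number here means that less compound is tolerated, a higher number that more compound is tolerated:
compound 1 `Cc1cc(O)cc(-c2nn(CC#N)cc2-c2ccnc(-c3ccc(Oc4ccccc4)cc3)c2)c1` — 41400 nM
compound 2 `COc1cc(C)cc(-c2nn(CC#N)cc2-c2ccnc(-c3ccc(N(C)C)cc3)c2)c1` — > 100000 nM

Compound 2 stands at a limit of the assay, not at a number; it sits at the limit of > 100000 nM in this assay, at which 1 of the 2 values shown sits. Compound 1, by contrast, gives a measured value. Compound 3 `Cc1cc(O)cc(-c2nn(CC#N)cc2-c2ccnc(-c3ccc(N(C)C)cc3)c2)c1` arises from compound 2 by hydrogen in place of methyl on an oxygen on an aromatic ring. For the measured compounds named here, no measured pair shows this change on its own, so its direction is open. The expected step, an at least 1.4-fold lower number from compound 2 to compound 3 (0.15 log units; that floor lies within the scatter), is small, likely none beyond the scatter. For compound 3 a value of 70000 nM is expected in this assay, within 25000 nM to 200000 nM, with a fair chance that only a limit is reported again.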

Compound 3, concentration lethal to 50% of the cells: > 100000 nM
Compound 3: no number, only a limit; the forecaster's own chance of this, stated with the estimate: 45%; at least 1.4-fold (0.15 log units) between middle value and limit.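

With methoxy changed to hydroxy, compound 3 remains at a limit of the assay in this assay, as does compound 2, so the step between them cannot be read: the limit of > 100000 nM in this assay, at which 2 of the 3 values shown sit.

For the compounds shown here, with hydroxy common to both compounds, dimethylamino in place of phenoxy on an aromatic carbon gives an at least 2.4-fold higher number from compound 1 to compound 3 (0.38 log units; beyond the scatter), the only readable step here.

Still open, from the compounds shown here alone, is whether methoxy and hydroxy differ when phenoxy is present, where a measured value may be obtainable. Also open, going by these compounds, is what a primary amine or a carboxylic acid gives in place of dimethylamino.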